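Trimming a methyl from the ketone side chain

The source may hold more compounds than are shown below. What is called first, only, known or untested is meant among the compounds shown, and "the series" means these compounds.

Compound 1 `Cc1c(OCCCCOc2ccccc2C(=O)O)ccc(C(=O)CC2CCCC2)c1C` gives "not determined" (no result reported) in an assay on HEK293 cells for positive allosteric modulation of metabotropic glutamate receptor 3 (Rattus norvegicus), read by thallium flux, with a stated time of 2.5 min (a lower number here means that less compound is needed, a higher number that more compound is needed for the effect), so no result is recorded for it. For the measured compounds named here, compound 2 `COc1cc(C(=O)O)ccc1OCCCCOc1ccc(C(=O)CC(C)(C)C)c(O)c1C` gives 310 nM in this assay, the single number available, so there is no comparison against a measured neighbour. Compound 3 `COc1cc(C(=O)O)ccc1OCCCCOc1ccc(C(=O)CC(C)C)c(O)c1C` differs from compound 2 only by hydrogen in place of methyl on a saturated chain carbon bound to three saturated chain carbons, the change read one bond out as tert-butyl to isopropyl. Going by the values given here, no step between measured compounds exists to anchor this. With one carbon removed from a saturated chain, the step of a 1.4-fold higher number from compound 2 to compound 3 (0.13 log units; within the scatter) is expected to be small, at most a slight loss. Compound 3 is estimated at 420 nM, within 150 nM to 1200 nM.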

Compound 3, half-maximal effective concentration: 614 nM
The estimate for compound 3 lay 1.5-fold (0.16 log units) below the measured number; the range from low to high includes it.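

In this assay, for the compounds shown here, hydrogen in place of methyl on a saturated chain carbon bound to three saturated chain carbons gives a 2.0-fold higher number from compound 2 to compound 3 (0.30 log units; within the scatter) and provides the first measured step at this position. Across this one change, tert-butyl to isopropyl, the values of the pair stay within the usual scatter, so the methyl shows no measurable contribution here. No measurement on hand bears on a cause for this step.

Steps involving compound 1 cannot be read, as it has no numerical result. Going by these compounds, whether an amine or a longer chain at this position would keep the value also remains open.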